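This account rests on a few compounds, and the source may have more. Where it says the series, first, only, none or still open, it means among the compounds named here.

Working notes, bile acid receptor series.

Compound 2 `Cc1cccc(COc2ccc(C(=O)Nc3cccc(C(=O)O)c3)cc2)c1` and compound 1 `CC(C)CCOc1ccc(C(=O)Nc2cccc(C(=O)O)c2)cc1` share a core and differ only at the saturated chain carbon bound to an oxygen on an aromatic ring. Among the measured compounds shown here, in an assay on isolated protein for agonist activity at Bile acid receptor (Homo sapiens), read by TR-FRET, with a stated time of 3 h, in the absence of a further agent (on this read-out lower numbers stand for an effect already at smaller amounts and higher numbers for an effect only at larger amounts of compound), compound 2 gives 259 nM and compound 1 gives 215 nM; the step of a 1.2-fold higher number from compound 1 to compound 2 (0.08 log units; within the scatter) is within the scatter, so on the numbers so far compound 2 cannot be told apart from compound 1, although it carries the numerically higher of the two.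

Compound 3 `CO/N=C(/COc1ccc(C(=O)Nc2cccc(C(=O)O)c2)cc1)c1ccccc1` is the next change at the same place: a group of 10 heavy atoms (8 carbon, 1 nitrogen, 1 oxygen; one six-membered aromatic ring of carbon only) in place of a group of 7 heavy atoms (7 carbon; one six-membered aromatic ring of carbon only), on a saturated chain carbon bound to an oxygen on an aromatic ring. For the measured compounds named here, the only measured step that bears on this position is the one from compound 1 to compound 2, and it was within the scatter, which indicates that this position tolerates exchange of the isobutyl for an aromatic group without a visible move in this assay. Going by the values given here, the entering group is larger and brings acceptors, for which no precedent exists in the two measured compounds. The expectation is therefore a step of a 1.2-fold higher number from compound 2 to compound 3 (0.09 log units; within the scatter) in this assay, not clearly beyond the scatter, with a slight lean toward a higher number. Compound 3 is estimated at 320 nM, with a range of 120 nM to 850 nM.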

Compound 3, half-maximal effective concentration: > 10000 nM
Compound 3 gave a limit, no number; the forecaster's own chance of this, stated with the estimate: 5%; middle value at least 31-fold (1.49 log units) away from the limit.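

Compound 3 gives no number in this assay, only a limit of the assay: the limit of > 10000 nM in this assay, at which 1 of the 3 values shown sits.

Read against that limit, the entering group gives an at least 38-fold higher number from compound 2 to compound 3 (1.58 log units; beyond the scatter) and an at least 46-fold higher number from compound 1 to compound 3 (1.66 log units; beyond the scatter), both beyond the scatter. The earlier pair suggested that this place, on a saturated chain carbon bound to an oxygen on an aromatic ring, accepts a change of group without a visible move, but compound 3 shows that this tolerance does not extend to every group placed there.

The entering group differs from 3-methylphenyl at once in its heavy atoms, its double bond outside aromatic rings and its hydrogen-bond acceptors, so the compounds shown cannot say which of these differences goes with the step. On these data alone, it also remains open whether a longer chain, an amine or a carboxylic acid at this place would stay near compound 1 and compound 2 or would also end at a limit.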